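The source may report more compounds than this note shows. Statements on the series, on what has been measured and on what is new or still open speak of the compounds shown alone.

Compound 2 `O=C1Nc2ccccc2/C1=C\c1c(Cl)n(Cc2ccccc2)c2ccccc12` gives 20400 nM in a functional assay on cells (Cancer cell lines, Homo sapiens) for cytotoxicity, with a stated time of 48 h (on this read-out higher numbers stand for weaker inhibition of growth and lower numbers for stronger inhibition of growth), the highest of the three numbers in hand. Compound 1 `COc1cc2c(/C=C3/C(=O)Nc4ccc(O)cc43)c(Cl)n(Cc3cc(OC)c(OC)c(OC)c3)c2cc1C` gives 2750 nM in this assay, and compound 3 `COc1cc2c(/C=C3/C(=O)Nc4ccc(Cl)cc43)c(Cl)n(Cc3cc(OC)c(OC)c(OC)c3)c2cc1C` gives 2950 nM in this assay, so both sit well below compound 2. Within the data shown here, the only measured single step, a 1.1-fold higher number from compound 1 to compound 3 (0.03 log units; within the scatter), concerns a substituent on the core and does not touch the chain on the aromatic nitrogen. The change to compound 4 `O=C1Nc2ccccc2/C1=C\c1c(Cl)n(CCCc2ccccc2)c2ccccc12` is phenethyl in place of phenyl on a saturated chain carbon bound to an aromatic nitrogen. Among the measured compounds shown here, no measured pair speaks to lengthening that chain, so no step beyond the scatter is expected. The estimated step is a 1.1-fold lower number from compound 2 to compound 4 (0.05 log units; within the scatter). Compound 4 is therefore expected near 18000 nM, within 6000 nM to 50000 nM.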

Compound 4, concentration for 50% growth inhibition: 13800 nM
The estimate for compound 4 lay 1.3-fold (0.12 log units) above the measured number; the range from low to high includes it.
By their numbers in this assay, from the lowest: compounds 1 and 3 (each within the scatter of the next); then compounds 4 and 2 (each within the scatter of the next).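

In this assay, among these compounds, the change from benzyl to 3-phenylpropyl on the aromatic nitrogen gives a 1.5-fold lower number from compound 2 to compound 4 (0.17 log units; within the scatter) and so is the first step read at this position. Across this pair, the longer chain leaves the read-out within the scatter, so the position accepts the added length without a measurable change. Nothing at hand offers an explanation for this result.

Still open, as far as these compounds go, is how an amine or a carboxylic acid at the end of this chain, or a longer chain, would read. Also open, from the compounds shown here alone, is whether the same change holds on the core of compound 1.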